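The compounds below may be only part of what the source reports. "The series", "measured", "known", "first", "only" and "open" are said of these compounds alone.

Measured so far:
Compound 1 `O=C(/C=C/c1ccc(O)cc1)c1c(O)cccc1OCC1CCCCC1`: in a functional assay on MDA-MB-231 cells (Homo sapiens) for antiproliferative activity, read by sulforhodamine B assay (a lower number here means a stronger inhibitor of growth, a higher number a weaker inhibitor of growth), compound 1 gives > 30000 nM, a limit of the assay.
Compound 2 `CC(C)=CCOc1cccc(O)c1C(=O)/C=C/c1ccc(O)cc1`: in this assay compound 2 gives > 30000 nM, again a limit.
Compound 3 `COc1cccc(OCCC(C)(C)C)c1C(=O)/C=C/c1ccc(O)cc1`: in this assay compound 3 gives > 30000 nM, again a limit.

Compound 2 therefore stands only at a limit, as do both other compounds shown, all of them at the limit of > 30000 nM in this assay, at which 3 of the 3 values shown sit. For the measured compounds named here, the single step between measured neighbours, a step that the two limits leave unreadable from compound 1 to compound 2, is left unreadable by those two limits. The next compound is compound 4 `CC(C)CCOc1cccc(O)c1C(=O)/C=C/c1ccc(O)cc1`, which differs from compound 2 by isobutyl in place of 2-methylprop-1-en-1-yl on a saturated chain carbon bound to an oxygen on an aromatic ring. Going by the values given here, no measured step bears on this change, and compound 3 with its own chain variation also sits at the limit. A step beyond the scatter is not expected; a step that the limit leaves unreadable from compound 2 to compound 4 is the estimated step. Compound 4 is expected at 35000 nM, within 15000 nM to 90000 nM, most probably reported again only as a limit.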

Compound 4, concentration for 50% growth inhibition: 10300 nM
Beside the measured number, compound 4's estimate is 3.4-fold (0.53 log units) above it, outside the stated range (below it).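

Saturating the side chain gives the only value shown that is not a limit: in this assay, isobutyl in place of 2-methylprop-1-en-1-yl gives an at least 2.9-fold lower number from compound 2 to compound 4 (0.46 log units; beyond the scatter). At the same place, isobutyl in place of cyclohexyl gives an at least 2.9-fold lower number from compound 1 to compound 4 (0.46 log units; beyond the scatter), so a ring on this chain is not required for a measurable value. Both steps are lower bounds, with compound 1 and compound 2 each at a limit: the limit of > 30000 nM in this assay, at which 3 of the 4 values shown sit.

From the compounds shown here alone, whether a longer chain such as n-hexyl would give a lower number remains open, as does the effect of a terminal amine on this chain.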